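The source may report more compounds than this note shows. Statements on the series, on what has been measured and on what is new or still open speak of the compounds shown alone.

Measured so far in a functional assay on NCI-H630 cells (Homo sapiens) for cytotoxicity, read by sulforhodamine B assay, with a stated time of 5 days (on this read-out lower numbers stand for stronger inhibition and higher numbers for weaker inhibition), for this series:
- Compound 1 (`O=C(CCCCCCCCCCc1ccccc1)N[C@H]1CCOC1=O`) gives 70000 nM
- Compound 2 (`O=C(CCCCCCCCCCc1ccccc1)CC(=O)N[C@H]1CCOC1=O`) gives 23000 nM

Compound 2 has the lower of the two numbers, and its gap to compound 1 lies beyond the scatter. It is therefore the stronger of the pair on this read-out.

Compound 3 (`O=C(CCCCCCCCCc1ccccc1)CC(=O)N[C@H]1CCOC1=O`) has not yet been measured. Its difference from compound 2 is phenyl in place of benzyl on a saturated chain carbon, nine bonds along the chain from a carbonyl carbon. The rest of the structure is unchanged. Among the measured compounds shown here, no measured pair shows a change of this kind, so the expectation is poorly anchored and the range is kept wide. In this assay the estimated 1.1-fold higher number from compound 2 to compound 3 (0.04 log units; within the scatter) is expected to stay within the scatter, with no clear direction. For compound 3 the estimated value is 25000 nM (expected range 10000 nM to 60000 nM).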

Compound 3, half-maximal inhibitory concentration: 16000 nM
Estimate against measurement, compound 3: 1.6-fold (0.19 log units) above; low and high end bracket the measured number.
By their numbers in this assay, from the lowest: compounds 3 and 2 (each within the scatter of the next); then compound 1.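

Phenyl in place of benzyl on a saturated chain carbon, nine bonds along the chain from a carbonyl carbon, gives a 1.4-fold lower number from compound 2 to compound 3 (0.16 log units; within the scatter) in this assay. Among the compounds shown here, this is the first reading of a change at this position, and it shows that this exchange of benzyl for phenyl does not move the number beyond the scatter, so compound 2 and compound 3 cannot be ranked on this read-out. No supporting data are available to explain this result.

From the compounds shown here alone, whether the position stays as insensitive with a different kind of group, such as an amine or a carboxylic acid in place of the phenyl, remains open. Going by these compounds, a much shorter or much longer chain also remains untested in these compounds, so a single step within the scatter sets no limit on the chain length.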